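Second methoxy on the arylsulfonamide: growth inhibition expected

The source may hold more compounds than are shown below. What is called first, only, known or untested is meant among the compounds shown, and "the series" means these compounds.

The series shares one core, differing only in the aryl sulfonamide. Compound 1 is `O=S(=O)(NC1=NCCN1C(=S)SN1CCn2c1nsc2=S)c1ccccc1`. In a functional assay on KYSE-510 cells (Homo sapiens) for antiproliferative activity, read by crystal violet staining, with a stated time of 96 h (a higher number here means a weaker inhibitor of growth, a lower number a stronger inhibitor of growth), compound 1 gives only a limit of the assay, >= 20000 nM. Compound 2 is `COc1ccc(S(=O)(=O)NC2=NCCN2C(=S)SN2CCn3c2nsc3=S)cc1`. In this assay compound 2 likewise gives only a limit, >= 20000 nM. The step that the two limits leave unreadable from compound 1 to compound 2 therefore cannot be sized; its two values rest on (the limit of >= 20000 nM in this assay, at which 2 of the 2 values shown sit).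

Compound 3 is `COc1ccc(S(=O)(=O)NC2=NCCN2C(=S)SN2CCn3c2nsc3=S)cc1OC`. It differs from compound 2 by methoxy in place of hydrogen on an aromatic carbon. Among the measured compounds shown here, the only measured step that bears on this change is a step that the two limits leave unreadable from compound 1 to compound 2, which is itself unreadable, so no size or direction can be drawn from it for this assay. For the measured compounds named here, the first methoxy left the value at the limit, and nothing in the measured pair suggests that a second methoxy would move it off the limit. For compound 3 the estimate in this assay is 30000 nM (range 10000 nM to 100000 nM). This corresponds to an expected step that the limit leaves unreadable from compound 2 to compound 3, with the result most likely again reported only as a limit.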

Compound 3, concentration for 50% growth inhibition: >= 20000 nM
Compound 3: a limit, no number (the forecaster's own chance of this, stated with the estimate: 85%); the middle value does not contradict the limit.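

Compound 3 gives only a limit in this assay, >= 20000 nM. No step among compound 1, compound 2 and compound 3 can be read, since all three values are limits: the limit of >= 20000 nM in this assay, at which 3 of the 3 values shown sit.

The compounds shown leave open whether any change to the aryl sulfonamide on the shared core can bring growth inhibition to a readable value in this assay.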